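The compounds below may be only part of what the source reports. "The series", "measured", "known", "first", "only" and "open" are said of these compounds alone.

Working notes on the series, step from compound 2 to compound 3.

Compound 2 `O=C1c2ccccc2O[C@H](c2cccc(O)c2O)[C@H]1O` stands at the weak end of what has been measured: in a functional assay on RAW264.7 cells (Rattus norvegicus) for inhibition, with RAW264.7 (Mus musculus) as the target, read by Griess assay, with stated times of 2 h and 16 h (a lower number here means a stronger inhibitor, a higher number a weaker inhibitor), compound 2 gives > 100000 nM, which is a limit of the assay and not a number. Going by the values given here, the only measured neighbour is compound 1 `O=C1c2c(O)cccc2O[C@H](c2cccc(O)c2O)[C@H]1O`, which in this assay gives 77700 nM. Among the compounds with values here, the step of an at least 1.2-fold higher number from compound 1 to compound 2 (0.10 log units; that floor lies within the scatter) is the single measured step that bears on the present change, and it is small; the value of compound 2 sits at the limit of > 100000 nM in this assay, at which 1 of the 2 values shown sits, so the true size of that step is not known.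

Compound 3 `COc1ccc2c(c1)O[C@H](c1cccc(O)c1O)[C@@H](O)C2=O` differs from compound 2 by methoxy in place of hydrogen on an aromatic carbon. Within the data shown here, no measured step adds a methoxy at any position, so the change from compound 2 to compound 3 has no direct precedent; the one known step on this ring moved the number only within the scatter. A step that the limit leaves unreadable from compound 2 to compound 3 is therefore expected, with no clear direction beyond the scatter. For compound 3 in this assay the estimate is 120000 nM, within 40000 nM to 400000 nM, with a real chance that only a limit is reported.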

Compound 3, half-maximal inhibitory concentration: 24600 nM
Compound 3: middle estimate off by 4.9-fold (0.69 log units), on the high side; the measured number lies below the stated range.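

In this assay, methoxy in place of hydrogen on this aromatic carbon gives a step that reads beyond the scatter: the series moves by an at least 4.0-fold lower number from compound 2 to compound 3 (0.60 log units; beyond the scatter) on this one change. The earlier step on this ring, an at least 1.2-fold higher number from compound 1 to compound 2 (0.10 log units; that floor lies within the scatter), could not show that a substituent here moves the number, since its floor lies within the scatter. Going by these compounds, the present step has a floor only and its true size remains unknown, since the value of compound 2 is a limit and not a number: the limit of > 100000 nM in this assay, at which 1 of the 3 values shown sits.

Whether this gain belongs to methoxy itself or would also come with another group at this carbon stays open, since no hydroxy, ethoxy, amine or fluorine stands here in the compounds shown. On these data alone, whether methoxy acts alike on other carbons of this ring also stays open.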